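Working notes on the series: compound 2 to compound 3

The source may hold more compounds than are shown below. What is called first, only, known or untested is meant among the compounds shown, and "the series" means these compounds.

Compound 1 `Cc1ccccc1OS(=O)(=O)c1ccc(NC(=O)NCCCCl)cc1` in a functional assay on MCF7 cells (Homo sapiens) for cytotoxicity, read by sulforhodamine B assay, with a stated time of 48 h (a higher number here means a weaker inhibitor, a lower number a stronger inhibitor), gives 27000 nM. Compound 2 `Cc1ccccc1NS(=O)(=O)c1ccc(NC(=O)NCCCCl)cc1` in this assay gives > 200000 nM, which is a limit of the assay and not a number. Between them stands an at least 7.4-fold higher number from compound 1 to compound 2 (0.86 log units; beyond the scatter), and because of the limit of > 200000 nM in this assay, at which 1 of the 2 values shown sits, the full size of that step remains open. Compound 3 `CCc1ccccc1NS(=O)(=O)c1ccc(NC(=O)NCCCCl)cc1` differs from compound 2 by methyl in place of hydrogen on a saturated chain carbon bound to an aromatic carbon. Among the compounds with values here, no measured step touches this position, so the only footing is compound 2 itself. Compound 3 is therefore expected to stay near the limit, with a step that the limit leaves unreadable from compound 2 to compound 3 not beyond the scatter. Compound 3 is estimated at 250000 nM, between 100000 nM and 700000 nM.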

Compound 3, half-maximal inhibitory concentration: > 200000 nM
Compound 3 was reported as a limit (the forecaster's own chance of this, stated with the estimate: 75%); the middle value does not contradict the limit.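

No new step can be read from compound 2 to compound 3, because both stand at a limit of the assay: the limit of > 200000 nM in this assay, at which 2 of the 3 values shown sit.

The compounds shown leave open how far methyl in place of hydrogen on a saturated chain carbon bound to an aromatic carbon shifts the number in this assay.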